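The source may report more compounds than this note shows. Statements on the series, on what has been measured and on what is new or still open speak of the compounds shown alone.

Measured compounds:
Compound 1, `O[C@H](COCCOC[C@@H](O)Cc1cn(Cc2ccc3ccccc3c2)nn1)Cc1ccc(-c2ccccc2)cc1`: 12100 nM in a functional assay on SGC-7901 cells (Homo sapiens) for inhibition, read by MTT assay, with a stated time of 72 h; a lower number here means a stronger inhibitor of growth, a higher number a weaker inhibitor of growth
Compound 2, `O=C1COc2ccc(-n3cc(C[C@H](O)COCCOC[C@@H](O)Cc4ccc(-c5ccccc5)cc4)nn3)cc2N1`: 15200 nM in this assay

Two compounds share a core and differ only in the group on an aromatic nitrogen. The step of a 1.3-fold higher number from compound 1 to compound 2 (0.10 log units; within the scatter) is small, so the two numbers cannot be told apart, and compound 2 is simply one of two similar values, with compound 1 as its nearest neighbour.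

Compound 3, `O[C@H](COCCOC[C@@H](O)Cc1cn(-c2cccs2)nn1)Cc1ccc(-c2ccccc2)cc1`, has not yet been measured. It differs from compound 2 by a group of 5 heavy atoms (4 carbon, 1 sulfur; one five-membered aromatic ring with 1 hetero atom) in place of a group of 11 heavy atoms (8 carbon, 1 nitrogen, 2 oxygen; one six-membered non-aromatic ring with 2 hetero atoms, one six-membered aromatic ring of carbon only), on an aromatic nitrogen. Within the data shown here, only one measured step bears on a swap at this position, and that step, a 1.3-fold higher number from compound 1 to compound 2 (0.10 log units; within the scatter), stayed within the scatter. Nothing here points to a move beyond the scatter in either direction, so the expectation for this assay is a step of about a 1.2-fold lower number from compound 2 to compound 3 (0.07 log units; within the scatter). On that basis compound 3 is estimated at 13000 nM, with a likely range from 6000 nM to 30000 nM.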

Compound 3, concentration for 50% growth inhibition: 33400 nM
For compound 3 the middle estimate is 2.6-fold (0.41 log units) below the measured one, outside the stated range (above it).
By their numbers in this assay, from the lowest: compounds 1 and 2 (each within the scatter of the next); then compound 3.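

In this assay the group on the aromatic nitrogen can shift the number after all, which the first pair, with its step inside the scatter, did not show. Thiophen-2-yl in place of the group on compound 2 gives a 2.2-fold higher number from compound 2 to compound 3 (0.34 log units; beyond the scatter) and, in place of the (naphthalen-2-yl)methyl group on compound 1, gives a 2.8-fold higher number from compound 1 to compound 3 (0.44 log units; beyond the scatter) as well, so both steps point towards weaker inhibition of growth, though both are modest. No measurement offered here explains this shift.

Among these compounds, with only three groups, size and ring type cannot be separated, since the one group of 5 heavy atoms is also the only one containing sulfur. From the compounds shown here alone, whether a plain phenyl or a benzyl group on the same nitrogen would sit with compound 1 and compound 2 or with compound 3 remains open.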